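Swapping one group on compound 2

The source may hold more compounds than are shown below. What is called first, only, known or untested is meant among the compounds shown, and "the series" means these compounds.

Of the compounds shown here, two have numbers so far. In a functional assay for inhibition, with Homo sapiens as the target (a lower number here means tighter binding, a higher number weaker binding), compound 1 (`O=C(O)CC/C=C\CC1COC(c2ccc(Cl)cc2Cl)OC1c1cccnc1`) gives 891 nM, while compound 2 (`CSc1ccc(OC(C)(C)C2OCC(C/C=C\CCC(=O)O)C(c3cccnc3)O2)c([N+](=O)[O-])c1`) gives 4.47 nM. That is the lower of the two numbers, and the gap between them lies well beyond the usual scatter of repeats. Compound 3 (`Cc1ccc(OC(C)(C)C2OCC(C/C=C\CCC(=O)O)C(c3cccnc3)O2)cc1`) keeps the rest of compound 2 and changes one place: a group of 7 heavy atoms (7 carbon; one six-membered aromatic ring of carbon only) in place of a group of 11 heavy atoms (7 carbon, 1 nitrogen, 2 oxygen, 1 sulfur; one six-membered aromatic ring of carbon only), on an oxygen on a saturated carbon. A 4-methylphenyl group enters there, on an oxygen on a saturated carbon, in place of a larger group. Among the measured compounds shown here, no measured pair shows this change alone, so the expectation is loose. Compound 1 at 891 nM marks how high a number a related structure can reach. A moderate upward step beyond the scatter is expected, estimated as an 8.9-fold higher number from compound 2 to compound 3 (0.95 log units; beyond the scatter). For compound 3 the estimated value is 40 nM, with an expected range of 8 nM to 200 nM.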

Compound 3, dissociation constant: 631 nM
For compound 3 the middle estimate is 16-fold (1.20 log units) below the measured one; the measured number lies above the stated range.
By their numbers in this assay, from the lowest: compound 2; then compounds 3 and 1 (each within the scatter of the next).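

In this assay, putting 4-methylphenyl in place of the larger group gives a 140-fold higher number from compound 2 to compound 3 (2.15 log units; beyond the scatter) with the rest of the structure unchanged. Among the compounds shown here, this is the first direct view of this position: the group on the oxygen on a saturated carbon has a large effect on the number, and the larger group, with its nitrogen, oxygen and sulfur atoms, goes with much tighter binding here. No measurement shown explains why the number moves so far.

The group that leaves differs from 4-methylphenyl in several atoms at once, so the pair cannot show which of those atoms matter. From the compounds shown here alone, whether a smaller change, such as an amine or a methoxy group on the aromatic ring of this group, would recover the tighter binding remains open.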